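Moving the Ring Nitrogen: From Compound 3 to Compound 4

The source may hold more compounds than are shown below. What is called first, only, known or untested is meant among the compounds shown, and "the series" means these compounds.

Three compounds have so far been measured in an assay on isolated protein for inhibition of Fatty-acid amide hydrolase 1 (Homo sapiens); a higher number here means a weaker inhibitor, a lower number a stronger inhibitor:

Compound 1, `CCCCCC(=O)C(F)(F)F`, gives 28900 nM.
Compound 2, `CCCCCCCC/C=C\CCCCCCC(=O)c1ncc(-c2ccccc2)o1`, gives 320 nM.
Compound 3, `CCCCCCCC/C=C\CCCCCCC(=O)c1ncc(-c2ccccn2)o1`, gives 18 nM.

Compound 3 has the lowest number of the three in this assay. Its nearest neighbour is compound 2, and the furthest is compound 1; both gaps lie beyond the scatter, so compound 3 is the strongest inhibitor among the measured set.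

Compound 4, `CCCCCCCC/C=C\CCCCCCC(=O)c1ncc(-c2ccncc2)o1`, has not yet been measured. It differs from compound 3 in one place: pyridin-4-yl in place of pyridin-2-yl on an aromatic carbon.

Among the measured compounds shown here, only one measured step bears on this change. The step of an 18-fold lower number from compound 2 to compound 3 (1.25 log units; beyond the scatter) shows that bringing a ring nitrogen onto the six-membered ring at this position gave a large gain. For the measured compounds named here, compound 4 keeps a ring nitrogen but at a different position in the ring, and nothing among the measured compounds tells how much of the gain of compound 3 over compound 2 survives that move. The expectation is therefore a number between those of compound 2 and compound 3, with an expected step of a 5.0-fold higher number from compound 3 to compound 4 (0.70 log units; beyond the scatter) in this assay. On that basis compound 4 is estimated at 90 nM, with a range from 20 nM to 400 nM.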

Compound 4, inhibition constant: 56 nM
The estimate for compound 4 lay 1.6-fold (0.21 log units) above the measured number; the measured number falls inside the stated range.
By their numbers in this assay, from the lowest: compound 3; then compound 4; then compound 2; then compound 1.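

Compound 4 shows that in this assay the site of the ring nitrogen matters, and not only its presence: with the same atoms and the same counts of ring atoms and hydrogen-bond acceptors, pyridin-4-yl in place of pyridin-2-yl gives a 3.1-fold higher number from compound 3 to compound 4 (0.49 log units; beyond the scatter) on this aromatic carbon next to the ring oxygen. The nitrogen gain is nevertheless not confined to pyridin-2-yl, since the change from phenyl to pyridin-4-yl still gives a 5.7-fold lower number from compound 2 to compound 4 (0.76 log units; beyond the scatter) in the same assay. Pyridin-4-yl thus retains a real part of the improvement over phenyl, though a smaller one than an 18-fold lower number from compound 2 to compound 3 (1.25 log units; beyond the scatter) seen with pyridin-2-yl. No measurement shown here gives a reason for the difference between the two pyridine isomers.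

The compounds shown leave open how pyridin-3-yl, the remaining pyridine isomer, or a pyrimidine ring with a second ring nitrogen would fare at this position. They also leave open whether pyridin-2-yl would keep its edge over pyridin-4-yl if the long unsaturated chain were replaced by a shorter saturated chain.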